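Amino in place of chloro: what to expect

The compounds below may be only part of what the source reports. "The series", "measured", "known", "first", "only" and "open" are said of these compounds alone.

Measured so far:
compound 1, `O=C(N/N=C\c1cccc(O)c1)Nc1nnc(COc2ccc3ccccc3c2)o1`: 300 mg/kg
compound 2, `O=C(N/N=C(/c1ccccc1)c1ccc(O)cc1)Nc1nnc(COc2ccc3ccccc3c2)o1`: 300 mg/kg
compound 3, `C/C(=N/NC(=O)Nc1nnc(COc2ccc3ccccc3c2)o1)c1ccc(Cl)cc1`: 300 mg/kg

All three compounds share one core and differ only in the group carried on the amide-type nitrogen. In a functional assay on the whole organism (strain Swiss albino) with Mus musculus as the target, with a stated time of 4 h (a higher number here means that more compound is needed for the effect, a lower number that less compound is needed), compound 1 gives 300 mg/kg. In this assay compound 2 gives 300 mg/kg, and in this assay compound 3 gives 300 mg/kg. Compound 3 thus stands level with compounds 1 and 2 at the digits shown; the three values lie within the usual scatter of one another, so no order among them can be read.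

Compound 4, `C/C(=N/NC(=O)Nc1nnc(COc2ccc3ccccc3c2)o1)c1ccc(N)cc1`, has not yet been measured. It differs from compound 3 in one place: amino in place of chloro on an aromatic carbon.

Within the data shown here, only one measured step bears on this: no change at the digits printed from compound 1 to compound 3 (within the scatter). That step exchanged a whole ring-bearing group and still left the value unchanged, so an exchange of a single atom at one aromatic carbon is expected to do no more. Among the measured compounds shown here, no measured pair tests amino against chloro directly, which leaves the estimate uncertain.

Compound 4 is therefore expected to give 300 mg/kg, with a range from 150 mg/kg to 600 mg/kg. The expected step of no change at the digits printed from compound 3 to compound 4 (within the scatter) is estimated to stay within the scatter.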

Compound 4, minimum effective dose: 300 mg/kg
Beside the measured number, compound 4's estimate shows no gap at the digits printed; low and high end bracket the measured number.
By their numbers in this assay, from the lowest: compounds 1, 2, 3 and 4 (each within the scatter of the next).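

Amino in place of chloro is the first change shown at this aromatic carbon, and the reading no change at the digits printed from compound 3 to compound 4 (within the scatter) in this assay shows that this single-atom exchange on the ring leaves the dose where it stood. Chloro counts no hydrogen-bond donor or acceptor and amino counts one of each, so among these two compounds that difference in count comes with no readable shift in the dose needed. Among these compounds, the wider exchange on the amide-type nitrogen, now with an amino-bearing group, reads no change at the digits printed from compound 1 to compound 4 (within the scatter) as well, so compound 4 joins the earlier compounds at the same level and the whole set still offers no order to interpret.

As far as these compounds go, whether a carboxylic acid, a methoxy group or a longer chain on this same aromatic carbon would stay level in the same way remains open, as does whether any change to the shared core itself would move the dose. Nothing available explains why these compounds read alike, and that question stays unanswered here.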